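The source may report more compounds than this note shows. Statements on the series, on what has been measured and on what is new or still open speak of the compounds shown alone.

Compound 1 `Cc1ccc(CNC(=O)n2c(N)nc3ccccc32)cc1`: 0.567 h
Compound 2 `O=C(NCCCCc1ccccc1)n1cnc2ccccc21`: > 2 h

Among the measured compounds shown here, in a physicochemical assay for metabolic stability, read by HPLC, at pH 4.5, tested at 10 uM (on this read-out lower numbers stand for a shorter-lived compound and higher numbers for a longer-lived compound), compound 1 gives 0.567 h, the only number among the two values shown. Compound 2 gives > 2 h, which is a limit of the assay and not a number. Compound 3 `Nc1nc2ccccc2n1C(=O)NCc1ccccc1` differs from compound 1 in one place: hydrogen in place of methyl on an aromatic carbon. For the measured compounds named here, no step between measured compounds is available to guide the reading. This change is expected to move the half-life in this assay little, if at all, staying within the usual scatter, so the step of a 1.1-fold higher number from compound 1 to compound 3 (0.02 log units; within the scatter) is estimated to be small. Compound 3 is therefore expected to give 0.6 h, in the range 0.3 h to 1.2 h.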

Compound 3, half-life: 0.7 h
Compound 3: middle estimate off by 1.2-fold (0.07 log units), on the low side, within the range that was stated.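

In this assay, the step of a 1.2-fold higher number from compound 1 to compound 3 (0.09 log units; within the scatter) shows that the methyl on the aromatic carbon, para to a large group, can give way to hydrogen without moving the half-life beyond the scatter. Among the compounds shown here, the earlier compounds offered no step at this position, so this pair gives the first reading of it, and 4-methylphenyl and phenyl cannot be told apart here. No measured property shown bears on this step.

The compounds shown leave open how a chlorine atom, a methoxy group or an amine at the same place would read. They also leave open whether the same change would read alike on another core.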